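Selenocyanate chain extension from the aminoethoxy anchor of compound 1

The source may report more compounds than this note shows. Statements on the series, on what has been measured and on what is new or still open speak of the compounds shown alone.

Measured so far in a functional assay on RKO cells (Homo sapiens) for inhibition, read by MTT assay, with a stated time of 48 h; on this read-out lower numbers stand for stronger inhibition and higher numbers for weaker inhibition:
compound 1 `COc1ccc(N(C)c2nc(C)nc3ccccc23)cc1OCCN` gives 343 nM
compound 2 `COc1ccc(N(C)c2nc(C)nc3ccccc23)cc1C(=O)NCC[Se]C#N` gives 1170 nM
compound 3 `Cc1nc(N(C)c2ccc([Se]C#N)c(F)c2)c2ccccc2n1` gives 8 nM

Compound 1 holds the second highest of the three numbers. Going by the values given here, its nearest neighbour is compound 2, and the one step that bears on the present question is a 3.4-fold higher number from compound 1 to compound 2 (0.53 log units; beyond the scatter), where a selenocyanate-bearing chain enters on an aromatic carbon of the shared core. Among the compounds with values here, compound 3 carries its selenocyanate directly on the aromatic ring and gives the lowest number of the set, but no single-point step links it to compound 1, so it offers no direct guide.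

Compound 4 `COc1ccc(N(C)c2nc(C)nc3ccccc23)cc1OCCCCCC[Se]C#N` differs from compound 1 by a group of 7 heavy atoms (5 carbon, 1 nitrogen, 1 selenium; no ring) in place of one nitrogen atom, on a saturated chain carbon, two bonds along the chain from an oxygen on an aromatic ring. Within the data shown here, the closest precedent, the step from compound 1 to compound 2, was modest and ran toward a higher number, although there the chain was attached through an amide rather than extended from the existing chain. The expectation for compound 4 in this assay is therefore a small move toward a higher number, a 1.6-fold higher number from compound 1 to compound 4 (0.21 log units; within the scatter), within broad uncertainty. The estimate for compound 4 is 550 nM, with a range from 150 nM to 2000 nM.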

Compound 4, half-maximal inhibitory concentration: 1540 nM
For compound 4 the middle estimate is 2.8-fold (0.45 log units) below the measured one; measured number inside the range.
By their numbers in this assay, from the lowest: compound 3; then compound 1; then compounds 2 and 4 (each within the scatter of the next).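

In this assay, the selenocyanate-bearing chain that enters in place of the amino group, on a saturated chain carbon, gives a 4.5-fold higher number from compound 1 to compound 4 (0.65 log units; beyond the scatter) and thus runs the same way as the amide-linked chain, which gives a 3.4-fold higher number from compound 1 to compound 2 (0.53 log units; beyond the scatter) in the same assay. Going by these compounds alone, the two chains are not told apart by this read-out, with a 1.3-fold higher number from compound 2 to compound 4 (0.12 log units; within the scatter) as the only step between them, so extending from the existing chain offers no visible gain over the amide link. No measured evidence is at hand to explain the rise in number on losing the amino group.

Open, going by these compounds, is whether the same chain ending in a thiocyanate or a plain methyl group would give a number like that of compound 4, which would separate the selenocyanate from the chain carrying it. Also open, on these data alone, is how a shorter chain, or one keeping a terminal amine, would read.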